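Replacing One Fluoro With Hydrogen in Compound 3

The source may report more compounds than this note shows. Statements on the series, on what has been measured and on what is new or still open speak of the compounds shown alone.

Compound 1 `COc1cc2c(Oc3ccc(NC(=O)c4nn(-c5ccccc5)cc(C)c4=O)cc3F)ccnc2cc1OCCCC(=O)NO` gives 1900 nM
Compound 2 `COc1cc2c(Oc3ccc(NC(=O)c4nn(-c5ccccc5F)cc(C)c4=O)cc3F)ccnc2cc1OCCCC(=O)NO` gives 2100 nM
Compound 3 `COc1cc2c(Oc3ccc(NC(=O)c4nn(-c5ccccc5F)cc(C)c4=O)cc3F)ccnc2cc1OCCCCCC(=O)NO` gives 2320 nM

All three values come from a functional assay on MCF7 cells (Homo sapiens) for inhibition, read by MTT assay, with a stated time of 72 h (a higher number here means a weaker inhibitor, a lower number a stronger inhibitor), and lie within the usual scatter of one another. Compound 3 (at 2320 nM) therefore cannot be told apart from compound 2 or compound 1.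

The next compound is compound 4 `COc1cc2c(Oc3ccc(NC(=O)c4nn(-c5ccccc5)cc(C)c4=O)cc3F)ccnc2cc1OCCCCCC(=O)NO`, which differs from compound 3 by a single change: hydrogen in place of fluoro on an aromatic carbon. In words, this is hydrogen in place of fluoro on an aromatic carbon, or 2-fluorophenyl to phenyl.

Among the compounds with values here, two measured steps bear on this. The same swap, run the other way on a shorter chain, gave a 1.1-fold higher number from compound 1 to compound 2 (0.04 log units; within the scatter). The change in chain between the other two compounds gave a 1.1-fold higher number from compound 2 to compound 3 (0.04 log units; within the scatter). Neither step stands out from the scatter, so no step beyond the scatter is expected in this assay. The expected change is small, with a 1.1-fold lower number from compound 3 to compound 4 (0.04 log units; within the scatter) as the estimated step.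

Compound 4 is estimated at 2100 nM with an expected range from 1300 nM to 3400 nM in this measurement.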

Compound 4, half-maximal inhibitory concentration: 2330 nM
For compound 4 the middle estimate is 1.1-fold (0.05 log units) below the measured one; measured number inside the range.
By their numbers in this assay, from the lowest: compounds 1, 2, 3 and 4 (each within the scatter of the next).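

In this assay, going from 2-fluorophenyl to phenyl leaves no readable difference on the chain of compound 3, with a 1.0-fold higher number from compound 3 to compound 4 (0.00 log units; within the scatter). The four compounds now form a closed square, so this swap can be compared on two chains, and it reads alike on both: the same change on two cores in this assay, a 1.1-fold higher number (0.04 log units; within the scatter) from compound 1 to compound 2 and a 1.0-fold lower number (0.00 log units; within the scatter) from compound 4 to compound 3, 1.1-fold (0.05 log units) apart, within the scatter of two such steps. The chain change can be checked in the same way, now without the fluoro, with a 1.2-fold higher number from compound 1 to compound 4 (0.09 log units; within the scatter), and it also reads alike in both pairs: the same change on two cores in this assay, a 1.1-fold higher number (0.04 log units; within the scatter) from compound 2 to compound 3 and a 1.2-fold higher number (0.09 log units; within the scatter) from compound 1 to compound 4, 1.1-fold (0.05 log units) apart, within the scatter of two such steps.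

Still open, going by these compounds, is whether a methoxy or an amine in place of the fluoro would give a step beyond the scatter. The same question stands for a longer chain, or for a carboxylic acid in place of hydroxycarbamoyl.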